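A few compounds are considered here, and "the series" means these few. Any claim that something is new, unique, unknown or untested is made for them only; others in the source may bear on it.

Working notes on the series. In a functional assay on A549 cells (Homo sapiens) for antiproliferative activity, read by sulforhodamine B assay, with a stated time of 48 h (a lower number here means a stronger inhibitor of growth, a higher number a weaker inhibitor of growth), compound 1 (`CC(C)CCc1c(OCCCCCCCC(=O)NO)ccc2ccc(=O)oc12`) gives 2190 nM and compound 2 (`CC(C)CCc1c(OCCCCCCCC(=O)NO)ccc(CCC(=O)NO)c1O`) gives 2670 nM. For the measured compounds named here, these two values lie within the usual scatter of each other, so compound 1 cannot be separated from the only other measured compound. Compound 3 (`CC(C)CCc1c(OCCCCCCC(=O)NO)ccc2ccc(=O)oc12`) keeps the core of compound 1 and has a shorter chain: hydroxycarbamoyl in place of (hydroxycarbamoyl)methyl on a saturated chain carbon, six bonds along the chain from an oxygen on an aromatic ring. This places hydroxycarbamoyl in place of (hydroxycarbamoyl)methyl on a saturated chain carbon, six bonds along the chain from an oxygen on an aromatic ring. Going by the values given here, no measured pair isolates this chain length, so the expectation starts from compound 1 at 2190 nM. A small expected move toward a higher number, hardly beyond the scatter, is estimated as a 1.2-fold higher number from compound 1 to compound 3 (0.07 log units; within the scatter). For compound 3 the estimated value in this assay is 2600 nM, with an expected range of 1100 nM to 6500 nM.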

Compound 3, concentration for 50% growth inhibition: 660 nM
The estimate for compound 3 lay 3.9-fold (0.60 log units) above the measured number; measured number below the stated range.
By their numbers in this assay, from the lowest: compound 3; then compounds 1 and 2 (each within the scatter of the next).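

In this assay the saturated chain carbon six bonds along from an oxygen on an aromatic ring proves sensitive to chain length: hydroxycarbamoyl in place of (hydroxycarbamoyl)methyl gives a 3.3-fold lower number from compound 1 to compound 3 (0.52 log units; beyond the scatter) on the shared core. For the compounds shown here, this is the first measured pair to isolate a single change, and the step lies beyond the scatter, so the shorter chain is a real difference in growth inhibition here. No measurement at hand bears on the origin of this step.

On these data alone, one step cannot establish a trend, so it remains open whether a still shorter chain would lower the number further or reverse it. Also open, as far as these compounds go, are whether the same shortening would carry over to the core of compound 2 and whether a carboxylic acid could replace the terminal hydroxycarbamoyl.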